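A Bromine Added to a Weaker Core

The compounds below may be only part of what the source reports. "The series", "measured", "known", "first", "only" and "open" are said of these compounds alone.

In a functional assay on DU-145 cells (Homo sapiens) for antiproliferative activity, read by MTT assay, with a stated time of 72 h (on this read-out lower numbers stand for stronger inhibition and higher numbers for weaker inhibition), compound 1 `O=C(COc1ccc(C(=O)/C=C/c2cccc(Br)c2)cc1)N[C@H]1CCOC1=O` gives 9800 nM, while compound 3 `O=C(COc1ccc(C(=O)/C=C/c2ccccc2)cc1)N[C@H]1CCOC1=O` gives 48300 nM. Compound 1 differs from compound 3 by bromo in place of hydrogen on an aromatic carbon, and that change gave a 4.9-fold lower number from compound 3 to compound 1 (0.69 log units; beyond the scatter). Compound 2 `O=C(CNc1ccccc1)N[C@H]1CCOC1=O` rests on a different core; the difference between the two cores is not broken down here. In this assay compound 2 reaches only a limit of the assay, > 64000 nM, which is the limit of > 64000 nM in this assay, at which 1 of the 3 values shown sits. Compound 4 `O=C(CNc1ccc(Br)cc1)N[C@H]1CCOC1=O` is compound 2 with bromo in place of hydrogen on an aromatic carbon, the same kind of change, though here the bromine sits para to a large group rather than meta to a large group. Compound 4 is expected to give 30000 nM, because the same kind of change gave a 4.9-fold lower number from compound 3 to compound 1 (0.69 log units; beyond the scatter). This expectation amounts to an at least 2.1-fold lower number from compound 2 to compound 4 (0.32 log units; beyond the scatter), and since compound 2 stands at a limit, compound 4 may also be reported only as a limit.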

Compound 4, half-maximal inhibitory concentration: > 64000 nM
Compound 4: only a limit was reported; the forecaster's own chance of this, stated with the estimate: 55%; at least 2.1-fold (0.32 log units) between middle value and limit.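

Compound 2 and compound 4 both stand at a limit of the assay, so no step can be read between them: the limit of > 64000 nM in this assay, at which 2 of the 4 values shown sit.

On these data alone, whether bromo in place of hydrogen lowers the number on the core of compound 2, as it did on the core of compound 3, stays open.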